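Notes on the step from compound 2 to compound 4

The compounds below may be only part of what the source reports. "The series", "measured", "known", "first", "only" and "open" are said of these compounds alone.

In a functional assay on HCT-116 cells (Homo sapiens) for cytotoxicity, read by sulforhodamine B assay, with a stated time of 24 h (a higher number here means a weaker inhibitor, a lower number a stronger inhibitor), compound 2 (`O=C1Nc2ccc(S(=O)(=O)N3CCOCC3)cc2/C1=N/c1cccc(C(F)(F)F)c1`) gives 15900 nM. That value lies within the scatter of compound 1 (`O=C1Nc2ccc(S(=O)(=O)N3CCOCC3)cc2/C1=N/c1ccc(O)cc1`) at 27300 nM and of compound 3 (`COc1ccc(-c2c(C#N)c(N)n(/N=C3\C(=O)Nc4ccc(S(=O)(=O)N5CCOCC5)cc43)c(=O)c2C#N)cc1`) at 18100 nM, so compound 2 cannot be ranked against either of them.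

Compound 4 (`O=C1Nc2ccc(S(=O)(=O)N3CCOCC3)cc2/C1=N/NC(=O)c1ccccc1`) has not yet been measured. It carries benzamido in place of 3-(trifluoromethyl)phenyl on a double-bonded nitrogen.

Among the compounds with values here, one measured step bears on this place: a 1.7-fold lower number from compound 1 to compound 2 (0.23 log units; within the scatter), where 3-(trifluoromethyl)phenyl replaces 4-hydroxyphenyl. That step stays within the scatter, but benzamido itself has not been tested, so the support is indirect. On that basis, no step beyond the scatter is expected in this assay, and no direction is favoured. The estimated step is a 1.1-fold higher number from compound 2 to compound 4 (0.05 log units; within the scatter). For compound 4 the estimated value is 18000 nM, with an expected range of 7000 nM to 45000 nM.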

Compound 4, half-maximal inhibitory concentration: 28900 nM
The estimate for compound 4 lay 1.6-fold (0.21 log units) below the measured number; low and high end bracket the measured number.
By their numbers in this assay, from the lowest: compounds 2, 3, 1 and 4 (each within the scatter of the next).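

In this assay, benzamido on a double-bonded nitrogen was compared with both aryl groups: in place of 3-(trifluoromethyl)phenyl it gives one step (a 1.8-fold higher number from compound 2 to compound 4 (0.26 log units; within the scatter)), and in place of 4-hydroxyphenyl it gives another (a 1.1-fold higher number from compound 1 to compound 4 (0.02 log units; within the scatter)). Both steps stay within the scatter, so this place accepts benzamido, with its carbonyl and the amide hydrogen, without a change that can be read in this measurement, and compound 4 cannot be ranked against compound 1 or compound 2. No measurement is available to explain this flat result.

The compounds shown leave open whether any group at this place can move the number beyond the scatter. An amine, a carboxylic acid or a longer alkyl chain on the double-bonded nitrogen would test this, as would a ring substituent on the benzamido group.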